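The source may hold more compounds than are shown below. What is called first, only, known or untested is meant among the compounds shown, and "the series" means these compounds.

Measured compounds:
compound 1 `CCOc1ncc(-c2nc(C(F)(F)F)sc2N2CCN(C(=O)Cn3ccc4cccnc43)[C@H](C)C2)cn1`, 47 nM in an assay on blood for inhibition of C-X-C chemokine receptor type 3 (Homo sapiens), with a stated time of 30 min; a higher number here means a weaker inhibitor, a lower number a stronger inhibitor
compound 2 `Cc1nc(C)n(CC(=O)N2CCN(c3sc(C(F)(F)F)nc3-c3cnc(OC4CCC4)nc3)C[C@H]2C)n1`, 306 nM in this assay

Compound 2 has the highest number of the two; the nearest is compound 1, whose half-maximal inhibitory concentration is lower by a margin beyond the scatter.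

Compound 3 `Cc1nc(C)n(CC(=O)N2CCN(c3sc(C(F)(F)F)nc3-c3cnc(C(C)(C)C)nc3)C[C@H]2C)n1` differs from compound 2 by tert-butyl in place of cyclobutyloxy on an aromatic carbon. For the measured compounds named here, no pair of measured compounds shows this change, so its size is unknown. The expected step is a 1.3-fold higher number from compound 2 to compound 3 (0.12 log units; within the scatter). Compound 3 is estimated at 400 nM, range 120 nM to 1300 nM.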

Compound 3, half-maximal inhibitory concentration: 1160 nM
The estimate for compound 3 lay 2.9-fold (0.46 log units) below the measured number; measured number inside the range.
By their numbers in this assay, from the lowest: compound 1; then compound 2; then compound 3.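

In this assay, the place between two ring nitrogen atoms does not tolerate every group alike: tert-butyl in place of cyclobutyloxy gives a clear loss (a 3.8-fold higher number from compound 2 to compound 3 (0.58 log units; beyond the scatter)). Cyclobutyloxy and tert-butyl are therefore not interchangeable here, at least with the rest of compound 2 held constant. Nothing available explains this step.

The oxygen and the four-membered ring leave together, so their shares in the step remain unresolved. Isopropoxy, which keeps the oxygen without the ring, and cyclobutyl, which keeps the ring without the oxygen, would separate the two.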